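Swapping Nitro for Hydroxy on a Weak Cell Inhibitor

This account rests on a few compounds, and the source may have more. Where it says the series, first, only, none or still open, it means among the compounds named here.

Of the compounds shown here, two sharing one core have been measured in a functional assay on A-431 cells (Homo sapiens) for inhibition, read by MTT assay, with a stated time of 72 h; a higher number here means a weaker inhibitor, a lower number a stronger inhibitor. Compound 1, `COc1ccc(-c2nnc(SCCCN3CCN(c4nc5ccccc5o4)CC3)o2)cc1`, gives 52700 nM. Compound 2, `O=[N+]([O-])c1ccc(-c2nnc(SCCCN3CCN(c4nc5ccccc5o4)CC3)o2)cc1`, gives 46900 nM. Among the measured compounds shown here, compound 2 thus stands at the smaller of the two numbers, but its only neighbour, compound 1, is so close that the pair cannot be told apart: the step of a 1.1-fold lower number from compound 1 to compound 2 (0.05 log units; within the scatter) lies within the scatter of repeated measurements.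

Compound 3, `Oc1ccc(-c2nnc(SCCCN3CCN(c4nc5ccccc5o4)CC3)o2)cc1`, has not yet been measured. It differs from compound 2 as follows: hydroxy in place of nitro on an aromatic carbon. For the measured compounds named here, no measured step exchanges nitro for hydroxy, so nothing bears directly on this change. Going by the values given here, the one step known, a 1.1-fold lower number from compound 1 to compound 2 (0.05 log units; within the scatter), exchanged one group for another on the same aromatic carbon and moved the number by no more than the scatter, so the group there has so far made little difference. On that basis compound 3 is expected to sit close to compound 2, with the step of a 1.1-fold higher number from compound 2 to compound 3 (0.03 log units; within the scatter) expected to stay within the scatter. The estimate for compound 3 in this assay is 50000 nM, within a range from 20000 nM to 125000 nM.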

Compound 3, half-maximal inhibitory concentration: 117000 nM
Beside the measured number, compound 3's estimate is 2.3-fold (0.37 log units) below it; the measured number falls inside the stated range.
By their numbers in this assay, from the lowest: compounds 2 and 1 (each within the scatter of the next); then compound 3.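

The position is less indifferent than the first pair suggested: in this assay, hydroxy in place of nitro gives a step beyond the scatter, a 2.5-fold higher number from compound 2 to compound 3 (0.40 log units; beyond the scatter), and the compound moves towards weaker inhibition. Taking only the methyl off the oxygen of compound 1 has a similar modest effect, a 2.2-fold higher number from compound 1 to compound 3 (0.35 log units; beyond the scatter), while nitro and methoxy could not be told apart, a 1.1-fold lower number from compound 1 to compound 2 (0.05 log units; within the scatter), so among these three groups hydroxy alone stands apart. Nothing available explains why this change raises the number.

Going by these compounds, it remains open whether the higher number goes with the hydrogen-bond donor that hydroxy brings and nitro lacks, and an amine or a carboxylic acid on this same carbon would give further cases against which to judge that idea. All three groups sit in one place, para to a large group, so the compounds shown do not tell how hydroxy would behave elsewhere on that ring or how a longer chain in the shared core would change the number.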